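Adding a Cyclopentenyl Ring to the Acetyl Chain

A few compounds are considered here, and "the series" means these few. Any claim that something is new, unique, unknown or untested is made for them only; others in the source may bear on it.

Compound 1 `CC(=O)N1CC2CC(C1)N2` gives 750 nM in an assay on CHO cells for agonist activity at Neuronal acetylcholine receptor; alpha3/alpha6/beta2/beta3 (Homo sapiens), read by FLIPR and calcium flux; a higher number here means that more compound is needed for the effect, a lower number that less compound is needed.
Compound 2 `O=C(C1CCCC1)N1CC2CC(C1)N2` gives 1600 nM in this assay.
Compound 3 `O=C(C1CC=CC1)N1CC2CC(C1)N2` gives 1900 nM in this assay.

Compound 1 has the lowest number of the three; compound 2 and compound 3 both sit higher, and both gaps lie beyond the usual scatter. Compound 4 `O=C(CC1C=CCC1)N1CC2CC(C1)N2` differs from compound 1 in one place: cyclopent-2-en-1-yl in place of hydrogen on a saturated chain carbon bound to a carbonyl carbon. The larger acyl groups of compound 2 (1600 nM) and compound 3 (1900 nM) each carry a higher number than compound 1, so a rise of roughly that size is expected here too, even though no change of exactly this kind has yet been measured. Compound 4 is therefore expected to give about 1500 nM (range 600 nM to 4000 nM), an expected step of a 2.0-fold higher number from compound 1 to compound 4 (0.30 log units; within the scatter).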

Compound 4, half-maximal effective concentration: 21000 nM
Compound 4: the middle estimate sits 14-fold (1.15 log units) below what was measured; the whole stated range lies below it.
By their numbers in this assay, from the lowest: compound 1; then compounds 2 and 3 (each within the scatter of the next); then compound 4.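

Replacing hydrogen with cyclopent-2-en-1-yl on a saturated chain carbon bound to a carbonyl carbon produces, in this assay, a 28-fold higher number from compound 1 to compound 4 (1.45 log units; beyond the scatter) and so costs far more than the estimate allowed. Going by these compounds alone, this is the first single change that can be read at this position, and it shows that the number here responds strongly to this group. Nothing available explains the size of this step.

On these data alone, it remains open whether a single methyl on this carbon would raise the number much less. An amine or an open longer chain there might also give a different step.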